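Ester chain length and the read-out in A549 cells

This account rests on a few compounds, and the source may have more. Where it says the series, first, only, none or still open, it means among the compounds named here.

Of the compounds shown here, two sharing one core have been measured so far. Compound 1 `CCCCOC(=O)CCC(=O)N1CCN(CCCOc2cc3c(Nc4ccc(F)c(Cl)c4)ncnc3cc2OC)CC1` is the shorter-chained of the pair; in a functional assay on A549 cells (Homo sapiens) for cytotoxicity, read by MTT assay, with a stated time of 24 h, tested at 60 uM (a lower number here means a stronger effect, a higher number a weaker effect of the compound at the concentration tested), compound 1 gives 64.1%. Compound 2 `CCCCCCCOC(=O)CCC(=O)N1CCN(CCCOc2cc3c(Nc4ccc(F)c(Cl)c4)ncnc3cc2OC)CC1` carries the longer chain, and in this assay compound 2 gives 35.7%. Compound 2 therefore stands lowest of the two numbers, with compound 1 the nearest and higher. Within the data shown here, the single step seen is a number 28.4 percentage points lower from compound 1 to compound 2 (beyond the scatter).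

Compound 3 `CCCCCCCCCCOC(=O)CCC(=O)N1CCN(CCCOc2cc3c(Nc4ccc(F)c(Cl)c4)ncnc3cc2OC)CC1` has not yet been measured. It differs from compound 2 by propyl in place of hydrogen on a saturated chain carbon, seven bonds along the chain from an oxygen next to a carbonyl group. Among the measured compounds shown here, this is the same kind of change as the one that separates compound 1 from compound 2, so that step bears on it directly; it was a modest fall, beyond the scatter. A further lowering in this assay is therefore expected, though compound 2 already sits at a low number and a fall of the same extent cannot be counted on. For compound 3 the step is expected to be a number 13.7 percentage points lower from compound 2 to compound 3 (beyond the scatter). The value expected for compound 3 in this assay is 22%, between 8% and 40%.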

Compound 3, a percentage reported as activity, at one concentration (the size of the read-out at that concentration, not a potency): 3.9%
Beside the measured number, compound 3's estimate is 18.1 percentage points above it; the whole stated range lies above it.
By their numbers in this assay, from the lowest: compound 3; then compound 2; then compound 1.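

In this assay the propyl change, now on a saturated chain carbon seven bonds along the chain from an oxygen next to a carbonyl group, gives a number 31.8 percentage points lower from compound 2 to compound 3 (beyond the scatter) and so shows that the fall did not die away as the chain grew, with compound 3 at 3.9% near the bottom of the percentage scale. Taken across the whole set, the change in chain length gives a number 60.2 percentage points lower from compound 1 to compound 3 (beyond the scatter) and the three numbers fall in step with chain length, with no compound going against that order. No measurement is at hand that would account for this fall.

The three compounds leave open whether a longer chain than that of compound 3 would hold this low number, and whether a branched chain or a chain ending in a carboxylic acid or an amine would behave alike. They also leave open whether the fall depends on the ester itself, since every compound carries it, and how it would look at other concentrations.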